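This account rests on a few compounds, and the source may have more. Where it says the series, first, only, none or still open, it means among the compounds named here.

Compound 1 `C=C(C)[C@@H]1CC=C(Cn2cc(COc3ccc(C4NC(=O)NC5=C4C(=O)CC(C)(C)C5)cc3)nn2)CC1` and compound 2 `C=C(C)[C@@H]1CC=C(Cn2cc(COc3cccc(C4NC(=O)NC5=C4C(=O)CC(C)(C)C5)c3)nn2)CC1` are built from the same atoms joined differently; the difference between the two cores is not broken down here. In an ADME assay on HaCaT cells (Homo sapiens) for inhibition, read by sulforhodamine B assay, with a stated time of 48 h (on this read-out lower numbers stand for stronger inhibition of growth and higher numbers for weaker inhibition of growth), compound 1 gives 436000 nM, while compound 2 gives 36400 nM. Compound 3 `C=C(C)[C@@H]1CC=C(Cn2cc(COc3cc(C4NC(=O)NC5=C4C(=O)CC(C)(C)C5)ccc3OC)nn2)CC1` is derived from compound 2 by methoxy in place of hydrogen on an aromatic carbon. In this assay compound 3 gives 451000 nM, so that a 12-fold higher number from compound 2 to compound 3 (1.09 log units; beyond the scatter).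

Compound 4 `C=C(C)[C@@H]1CC=C(Cn2cc(COc3ccc(C4NC(=O)NC5=C4C(=O)CC(C)(C)C5)cc3OC)nn2)CC1` has not yet been measured. Relative to compound 1 it carries methoxy in place of hydrogen on an aromatic carbon, again methoxy in place of hydrogen on an aromatic carbon. Among the measured compounds shown here, this is the same kind of change as the one between compound 2 and compound 3, but not the same: in compound 3 the methoxy sits ortho to a large group and para to a large group, whereas in compound 4 it sits ortho to a large group and meta to a large group.

For the measured compounds named here, only one measured pair shows this change. A rise in the number is expected because a 12-fold higher number from compound 2 to compound 3 (1.09 log units; beyond the scatter) points that way, yet compound 1 already stands at 436000 nM, close to compound 3 at 451000 nM. The expected step in this assay is therefore a 2.8-fold higher number from compound 1 to compound 4 (0.44 log units; beyond the scatter), judged somewhat smaller than the earlier one. Compound 4 is expected to give about 1200000 nM in this assay, with a likely range from 350000 nM to 4500000 nM, and a real chance that only a limit is reported.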

Compound 4, concentration for total growth inhibition: 71300 nM
For compound 4 the middle estimate is 17-fold (1.23 log units) above the measured one; measured number outside the range, below it.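

In this assay methoxy in place of hydrogen on an aromatic carbon gives a 6.1-fold lower number from compound 1 to compound 4 (0.79 log units; beyond the scatter), which here means stronger inhibition of growth on the core of compound 1. Set beside the earlier step, this result shows that the change does not carry from one core to the other in this series, since even the direction of the step reverses: the same change on two cores in this assay, a 12-fold higher number (1.09 log units; beyond the scatter) from compound 2 to compound 3 and a 6.1-fold lower number (0.79 log units; beyond the scatter) from compound 1 to compound 4, 76-fold (1.88 log units) apart, beyond the scatter of two such steps. It does not show what sets the two steps apart, as each core offers a single pair, the two cores differ from each other, and the methoxy of compound 4, ortho to a large group and meta to a large group, does not stand where the methoxy of compound 3 stands.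

The compounds shown leave open whether a hydroxyl, an ethoxy or a fluorine on the same aromatic carbon would follow the methoxy on each core, or whether each core would keep one direction across such groups. They also leave open whether a methoxy on another carbon of the same ring would follow either of the two steps seen here.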